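Trimming a Pyrrole to an Ethyl Group

The compounds below may be only part of what the source reports. "The series", "measured", "known", "first", "only" and "open" are said of these compounds alone.

Compound 1 `CN1CCN(CCCS(=O)(=O)c2ccc3nc(NC(=O)NC(=O)c4cc(-n5cccc5)ccc4Cl)sc3c2)CC1`: 0.15 nM
Compound 2 `CN1CCC(S(=O)(=O)c2ccc3nc(NC(=O)NC(=O)c4cc5c(cc4Cl)CCN5C)sc3c2)CC1`: 7.2 nM

In an assay on HEK293 cells for displacement of a labelled ligand from growth hormone secretagogue receptor type 1 (Homo sapiens), with a stated time of 60 min (on this read-out higher numbers stand for weaker inhibition and lower numbers for stronger inhibition), compound 1 gives 0.15 nM, the lower of the two measured numbers. Compound 2 gives 7.2 nM in this assay, a gap from compound 1 that lies beyond the scatter. Compound 3 `CCc1ccc(Cl)c(C(=O)NC(=O)Nc2nc3ccc(S(=O)(=O)CCCN4CCN(C)CC4)cc3s2)c1` differs from compound 1 by ethyl in place of 1H-pyrrol-1-yl on an aromatic carbon. For the measured compounds named here, no pair of measured compounds shows this change, so its size is unknown. The step of a 6.7-fold higher number from compound 1 to compound 3 (0.82 log units; beyond the scatter) is expected to be a modest rise, probably beyond the scatter. Compound 3 is estimated at 1 nM, with a range from 0.2 nM to 5 nM.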

Compound 3, half-maximal inhibitory concentration: 0.078 nM
Estimate against measurement, compound 3: 13-fold (1.11 log units) above; measured number outside the range, below it.
By their numbers in this assay, from the lowest: compounds 3 and 1 (each within the scatter of the next); then compound 2.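

On the aromatic carbon para to a chloro group, ethyl in place of 1H-pyrrol-1-yl gives, in this assay, a 1.9-fold lower number from compound 1 to compound 3 (0.28 log units; within the scatter). The five-membered aromatic ring is therefore not required for a number this low with the rest of compound 1 held constant: ethyl, with 2 heavy atoms against 5, serves equally well here. Nothing available explains why the two groups read alike. From the compounds shown here alone, whether a smaller methyl group, a longer propyl chain or an amine at this position would do the same remains open.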